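Moving the triple bond along the hydroxyalkynyl side chain

The compounds below may be only part of what the source reports. "The series", "measured", "known", "first", "only" and "open" are said of these compounds alone.

The three measured compounds share one core and differ at the chain attached to the five-membered ring and at the exocyclic double bond. In a functional assay for inhibition, with Homo sapiens as the target (on this read-out higher numbers stand for weaker inhibition and lower numbers for stronger inhibition), compound 2 `CC#CCC(C)[C@H](O)/C=C/[C@H]1[C@H](O)C[C@]2(C#CCCCO)C/C(=C\CCCC(=O)O)C[C@H]12` gives 10 nM and stands lowest of the three; compound 3 `CC#CCC(C)[C@H](O)/C=C/[C@H]1[C@H](O)C[C@]2(C#CCCCO)C/C(=C/CCCC(=O)O)C[C@H]12` gives 200 nM and compound 1 `CC#CCC(C)[C@H](O)/C=C/[C@H]1[C@H](O)C[C@]2(C#CCCCN=[N+]=[N-])C/C(=C/CCCC(=O)O)C[C@H]12` gives 850 nM. The step of a 20-fold higher number from compound 2 to compound 3 (1.30 log units; beyond the scatter) is the larger of the two measured steps, and the pair is notable because of the fact that one of compounds 2 and 3 is drawn with a defined configuration and the other without, at the place where they differ. The step of a 4.3-fold lower number from compound 1 to compound 3 (0.63 log units; beyond the scatter) is smaller and concerns the chain end rather than its length.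

Compound 4 `CC#CCC(C)[C@H](O)/C=C/[C@H]1[C@H](O)C[C@]2(CCC#CCCCO)C/C(=C\CCCC(=O)O)C[C@H]12` is not yet measured. It differs from compound 2 in this way: 7-hydroxyhept-3-yn-1-yl in place of 5-hydroxypent-1-yn-1-yl on a saturated ring carbon. Neither measured step bears on this change: the step from compound 1 to compound 3 alters the terminal group, and the step from compound 2 to compound 3 alters the double bond, while compound 4 keeps the hydroxy end and the double bond of compound 2 and only lengthens the chain and shifts the triple bond. For the measured compounds named here, with no guiding step, the expectation is a moderate weakening, a 3.0-fold higher number from compound 2 to compound 4 (0.48 log units; beyond the scatter), and compound 4 is estimated at 30 nM in this assay, within 5 nM to 200 nM.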

Compound 4, half-maximal inhibitory concentration: 400 nM
Compound 4: the middle estimate sits 13-fold (1.12 log units) below what was measured, and the stated range ends below it.
By their numbers in this assay, from the lowest: compound 2; then compounds 3 and 4 (each within the scatter of the next); then compound 1.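

In this assay, putting 7-hydroxyhept-3-yn-1-yl in place of 5-hydroxypent-1-yn-1-yl on this saturated ring carbon gives a 40-fold higher number from compound 2 to compound 4 (1.60 log units; beyond the scatter) and counts as a large step, even though the hydroxy end and the double bond of compound 2 stay as they are. For the compounds shown here, the earlier steps touched only the chain end and the exocyclic double bond, so this is the first sign that the chain itself matters at this position, next to the ring atom that bears a fused ring, and that the low number of compound 2 does not survive a change of this chain. Nothing at hand accounts for the size of this step.

Compound 4 carries a longer chain and a shifted triple bond together, so the compounds shown cannot tell which of the two drives the step. Also open, going by these compounds, is how a 5-hydroxypent-2-yn-1-yl chain, which moves the triple bond at the same length, a 7-hydroxyhept-1-yn-1-yl chain, which lengthens the chain with the triple bond in its old place, or an amine at the chain end would read in this assay.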